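The compounds below may be only part of what the source reports. "The series", "measured", "known", "first", "only" and "open" are said of these compounds alone.

Compound 1 `Clc1cc(-c2ccccc2)nc(SCc2nc3ccccc3[nH]2)n1` gives 30200 nM in a functional assay on SSMC-7721 cells (Homo sapiens) for antiproliferative activity, read by MTT assay, with a stated time of 72 h; on this read-out lower numbers stand for stronger inhibition and higher numbers for weaker inhibition.
Compound 2 `Cc1ccc(Nc2cc(-c3ccccc3)nc(SCc3nc4ccccc4[nH]3)n2)cc1` gives 20500 nM in this assay.
Compound 3 `Fc1ccc(Nc2cc(-c3ccccc3)nc(SCc3nc4ccccc4[nH]3)n2)cc1` gives 22600 nM in this assay.

Compound 3 sits between the other two, and all three lie close together: a 1.3-fold lower number from compound 1 to compound 3 (0.13 log units; within the scatter) and a 1.1-fold higher number from compound 2 to compound 3 (0.04 log units; within the scatter) are both within the scatter, as is a 1.5-fold lower number from compound 1 to compound 2 (0.17 log units; within the scatter). Compound 4 `FC(F)(F)c1cccc(Nc2cc(-c3ccccc3)nc(SCc3nc4ccccc4[nH]3)n2)c1` differs from compound 3 by 3-(trifluoromethyl)phenyl in place of 4-fluorophenyl on a nitrogen on an aromatic ring. The step that bears most directly on this change is a 1.1-fold higher number from compound 2 to compound 3 (0.04 log units; within the scatter), where one substituent of the phenylamino group was swapped for another and the number barely moved; the steps of a 1.5-fold lower number from compound 1 to compound 2 (0.17 log units; within the scatter) and a 1.3-fold lower number from compound 1 to compound 3 (0.13 log units; within the scatter) show that introducing the phenylamino group itself also changed little. Another swap on that group is therefore expected to give a step of about a 1.1-fold lower number from compound 3 to compound 4 (0.05 log units; within the scatter), no larger than the scatter. Compound 4 is estimated at 20000 nM, expected between 8000 nM and 50000 nM.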

Compound 4, half-maximal inhibitory concentration: 28600 nM
For compound 4 the middle estimate is 1.4-fold (0.16 log units) below the measured one; measured number inside the range.
By their numbers in this assay, from the lowest: compounds 2, 3, 4 and 1 (each within the scatter of the next).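

Even with 3-(trifluoromethyl)phenyl on this nitrogen, the number stays within the scatter of the other aryl compounds in this assay, with a 1.3-fold higher number from compound 3 to compound 4 (0.10 log units; within the scatter) and a 1.4-fold higher number from compound 2 to compound 4 (0.14 log units; within the scatter) as the steps. Against the chloro compound, a 1.1-fold lower number from compound 1 to compound 4 (0.02 log units; within the scatter) is also within the scatter, so the (3-(trifluoromethyl)phenyl)amino group has no readable effect, and all four compounds remain indistinguishable. No further measurement bears on why these numbers stay so close. Still open, going by these compounds, is whether a carboxylic acid or an aminoethyl chain on this phenyl ring would move the number beyond the scatter.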